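Swapping a ring amine on a shared core: compound 4

The source may report more compounds than this note shows. Statements on the series, on what has been measured and on what is new or still open speak of the compounds shown alone.

Three compounds have been measured in a functional assay on MCF7 cells (Homo sapiens) for antiproliferative activity, read by MTT assay, with a stated time of 72 h; on this read-out higher numbers stand for weaker inhibition and lower numbers for stronger inhibition:

Compound 1 `CCN1CCN(c2cc(C)c3cc(NC(=O)c4cccc(F)c4)ccc3n2)CC1`: 8920 nM
Compound 2 `Cc1cc(N2CCCCC2)nc2ccc(NC(=O)c3ccc(Cl)c(Cl)c3)cc12`: 31100 nM
Compound 3 `CCN1CCN(c2cc(C)c3cc(NC(=O)c4ccc[nH]4)ccc3n2)CC1`: 14700 nM

Compound 2 stands highest of the three; its nearest neighbour is compound 3 and its furthest is compound 1, both gaps beyond the scatter. Compound 4 `Cc1cc(N2CCN(C)CC2)nc2ccc(NC(=O)c3ccc(Cl)c(Cl)c3)cc12` differs from compound 2 in one place: 4-methylpiperazin-1-yl in place of piperidin-1-yl on an aromatic carbon. Going by the values given here, the only measured step, a 1.6-fold higher number from compound 1 to compound 3 (0.22 log units; within the scatter), alters the group on the carbonyl carbon, not the ring amine, so no measured step bears directly on this change. Compounds 1 and 3 give lower numbers than compound 2 but differ from it in two places, so they offer only loose guidance. A modest move toward a lower number is expected, a 1.6-fold lower number from compound 2 to compound 4 (0.19 log units; within the scatter). Compound 4 is estimated at 20000 nM, within 7000 nM to 60000 nM.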

Compound 4, half-maximal inhibitory concentration: 3000 nM
The estimate for compound 4 lay 6.7-fold (0.82 log units) above the measured number; measured number outside the range, below it.
By their numbers in this assay, from the lowest: compound 4; then compounds 1 and 3 (each within the scatter of the next); then compound 2.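

In this assay, the ring amine on the aromatic carbon next to the ring nitrogen proves to matter greatly: 4-methylpiperazin-1-yl in place of piperidin-1-yl gives a 10-fold lower number from compound 2 to compound 4 (1.02 log units; beyond the scatter) on an otherwise unchanged structure. The only other step shown alters the group on the carbonyl carbon and stays within the scatter, so this is the first large change seen. Nothing shown explains why this swap has so large an effect.

From the compounds shown here alone, it remains open whether the second ring nitrogen or its methyl group accounts for the drop. Piperazin-1-yl without the methyl, or morpholin-4-yl with an oxygen in that ring, would help separate the two.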